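Swapping the aryl group on a triazole nitrogen

A few compounds are considered here, and "the series" means these few. Any claim that something is new, unique, unknown or untested is made for them only; others in the source may bear on it.

Compound 3, `N#CC1=C(N)Oc2c(N)cc3nc4ccccc4nc3c2C12C(=O)N(Cc1cnnn1-c1ccccc1Cl)c1ccccc12`, is tested in a functional assay on MCF7 cells (Homo sapiens) for antiproliferative activity, read by MTT assay, with a stated time of 48 h; a lower number here means a stronger inhibitor, a higher number a weaker inhibitor. In this assay compound 3 gives 34400 nM. Compound 1, `N#CC1=C(N)Oc2c(c3nc4ccccc4nc3c3ccccc23)C12C(=O)N(Cc1cnnn1-c1cccc(Cl)c1)c1ccccc12`, gives 43600 nM in this assay, a number that lies within the scatter of compound 3. Compound 2, `Cc1cc(C)cc(-n2nncc2CN2C(=O)C3(C(C#N)=C(N)Oc4c3c3nc5ccccc5nc3c3ccccc43)c3ccccc32)c1`, reaches only a limit of this assay at > 50000 nM, and this is the case described by the limit of > 50000 nM in this assay, at which 1 of the 3 values shown sits.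

Compound 4, `CCc1cccc(C)c1-n1nncc1CN1C(=O)C2(C(C#N)=C(N)Oc3c(N)cc4nc5ccccc5nc4c32)c2ccccc21`, has not yet been tested. Compared with compound 3, the change is 2-ethyl-6-methylphenyl in place of 2-chlorophenyl on an aromatic nitrogen. Among the measured compounds shown here, the one measured step that resembles this change, an alkyl-substituted phenyl in place of a chlorophenyl on the same aromatic nitrogen, is an at least 1.1-fold higher number from compound 1 to compound 2 (0.05 log units; that floor lies within the scatter), which runs to a limit and cannot be sized beyond its floor. On that evidence the step is expected to be small, at most a modest weakening, so compound 4 is estimated at 45000 nM in this assay, within 20000 nM to 100000 nM. This corresponds to an expected step of a 1.3-fold higher number from compound 3 to compound 4 (0.12 log units; within the scatter).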

Compound 4, half-maximal inhibitory concentration: > 50000 nM
Compound 4: only a limit was reported; the forecaster's own chance of this, stated with the estimate: 40%; middle value at least 1.1-fold (0.04 log units) away from the limit.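

In this assay compound 4 is reported only as a limit, > 50000 nM. On the core of compound 3, the change from 2-chlorophenyl to 2-ethyl-6-methylphenyl on the aromatic nitrogen can be read only as an at least 1.4-fold higher number from compound 3 to compound 4 (0.16 log units; that floor lies within the scatter), which gives a floor and not a size. Alkyl-bearing phenyl groups now sit at this limit on both cores shown, in compound 2 and compound 4, while the two chlorophenyl compounds, compound 1 and compound 3, returned measured numbers: the limit of > 50000 nM in this assay, at which 2 of the 4 values shown sit.

From the compounds shown here alone, how far compound 2 and compound 4 lie past the limit stays open, so the two alkyl-bearing groups cannot be ranked against each other. Also open, going by these compounds, is whether an unsubstituted phenyl or a methoxyphenyl on the same nitrogen would give a measured number in this assay or stay at the limit.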